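The source may hold more compounds than are shown below. What is called first, only, known or untested is meant among the compounds shown, and "the series" means these compounds.

In an ADME assay on WI-38 cells (Homo sapiens) for cytotoxicity, read by MTT assay, with a stated time of 96 h (a higher number here means a weaker inhibitor, a lower number a stronger inhibitor), compound 1 (`COc1ccc(CN2CCN(c3ccc(C4CC(c5ccc([N+](=O)[O-])o5)=NO4)cc3)CC2)cn1`) gives > 50000 nM, which is a limit of the assay and not a number. Compound 2 (`O=[N+]([O-])c1ccc(C2=NOC(c3ccc(-c4cccnc4)cc3)C2)o1`) gives > 50000 nM, which is likewise a limit. The whole record so far is therefore (the limit of > 50000 nM in this assay, at which 2 of the 2 values shown sit), and neither compound can be placed in an order against the other.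

Compound 3 (`O=[N+]([O-])c1ccc(C2=NOC(c3ccc(N4CCN(Cc5ccncc5)CC4)cc3)C2)o1`) keeps the core of compound 1 and differs in one group: pyridin-4-yl in place of 6-methoxypyridin-3-yl on a saturated chain carbon bound to an amine nitrogen in a ring. In words, pyridin-4-yl stands in place of 6-methoxypyridin-3-yl on a saturated chain carbon bound to an amine nitrogen in a ring. The same difference can be read as (6-methoxypyridin-3-yl)methyl giving way to (pyridin-4-yl)methyl.

For the measured compounds named here, no pair of measured compounds shows a change of this kind, so the data give no direct guide to its size. The expectation rests on compound 1, whose limit is > 50000 nM, and no change beyond the usual scatter is expected in this assay. The expected step of a number no higher from compound 1 to compound 3 (the limit leaves the size open) is estimated to be within that scatter. For compound 3 the estimated value is 50000 nM, with an expected range from 25000 nM to 100000 nM.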

Compound 3, half-maximal inhibitory concentration: > 50000 nM
Compound 3: no number, only a limit (the forecaster's own chance of this, stated with the estimate: 80%); the middle value sits exactly at the limit.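

Compound 3, like compound 1, returns only a limit in this assay, so the step from one to the other cannot be read. The compounds shown leave open how far any of them stands from that limit, and whether the exchange of groups has any effect in this assay: the limit of > 50000 nM in this assay, at which 3 of the 3 values shown sit.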